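The compounds below may be only part of what the source reports. "The series", "measured", "known", "first", "only" and "open" are said of these compounds alone.

The account follows the step from compound 1 to compound 4 in an ADME assay on Caco-2 cells (Homo sapiens) for permeability, in the apical to basolateral direction; a higher number here means that the compound crosses the layer faster, a lower number that the compound crosses the layer more slowly. Compound 1, with the structure `CNC(=O)c1cc(Oc2ccc3nc(Nc4ccccc4)ncc3c2)ccn1`, reaches only a limit there: in this assay compound 1 gives < 1 10^-6 cm/s, which is a limit of the assay and not a number. Two close relatives stand in the same place. Compound 2, `CNC(=O)c1cc(Oc2ccc3nc(Nc4ccccc4Br)ncc3c2)ccn1`, also returns a limit in this assay, namely < 1 10^-6 cm/s. Compound 3, `CNC(=O)c1cc(Oc2ccc3nc(Nc4cccc(Br)c4)ncc3c2)ccn1`, likewise returns a limit in this assay, < 1 10^-6 cm/s. The steps among these three therefore cannot be read: a step that the two limits leave unreadable from compound 1 to compound 2, a step that the two limits leave unreadable from compound 1 to compound 3 and a step that the two limits leave unreadable from compound 2 to compound 3. What the series shows is summed up by the limit of < 1 10^-6 cm/s in this assay, at which 3 of the 3 values shown sit.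

Compound 4, `CNC(=O)c1cc(Oc2ccc3nc(Nc4ccc(OC(F)(F)F)cc4)ncc3c2)ccn1`, differs from compound 1 by trifluoromethoxy in place of hydrogen on an aromatic carbon. For the measured compounds named here, no measured step exchanges an aromatic hydrogen for trifluoromethoxy, and the steps that were measured yield no size, as the limit of < 1 10^-6 cm/s in this assay, at which 3 of the 3 values shown sit, records, so nothing can be carried over except that every measured compound sits at the limit. The step expected in this assay is an at least 1.2-fold higher number from compound 1 to compound 4 (0.07 log units; that floor lies within the scatter), which is to say no change that rises clearly beyond the scatter. For compound 4 the estimate in this assay is 1.2 10^-6 cm/s, expected within a range from 0.3 10^-6 cm/s to 4 10^-6 cm/s, with a real chance that compound 4 again returns only a limit.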

Compound 4, apparent permeability: < 1 10^-6 cm/s
Compound 4 gave a limit, no number (the forecaster's own chance of this, stated with the estimate: 55%); at least 1.2-fold (0.07 log units) between middle value and limit.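

Compound 4 gives < 1 10^-6 cm/s in this assay and that is a limit of the assay, not a number. For the compounds shown here, no step from compound 1, compound 2 or compound 3 to compound 4 can therefore be read: the limit of < 1 10^-6 cm/s in this assay, at which 4 of the 4 values shown sit. The compounds shown leave open how fast any of them crosses the layer, and whether bromo or trifluoromethoxy in place of hydrogen changes that at all.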